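The source may report more compounds than this note shows. Statements on the series, on what has been measured and on what is new or still open speak of the compounds shown alone.

Compound 2, `O=C(O)c1ccc(CCCN2C(=O)CC[C@@H]2CC[C@@H](O)Cc2ccc(F)cc2)s1`, was examined in a functional assay on HEK293 cells with prostaglandin E2 receptor EP4 subtype (Rattus norvegicus) as the target, read by cAMP accumulation (a lower number here means that less compound is needed, a higher number that more compound is needed for the effect), where it gives 22 nM. Among the three compounds with a number in this assay, compound 2 stands second highest. Its nearest neighbour is compound 1, `O=C(O)CCCCCCN1C(=O)CC[C@@H]1CCC(O)Cc1ccccc1`, which in this assay gives 32.5 nM, a difference that lies within the scatter of repeated measurements, so no order between the two can be claimed. The furthest is compound 3, `O=C(O)CCCCCCN1C(=O)CCC1CCC(O)Cc1cccc(Cl)c1`, which gives 8.8 nM in this assay, a number lower than that of compound 2 by more than the scatter.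

The step under consideration leads from compound 2 to compound 4, `O=C(O)c1ccc(CCCN2C(=O)CC[C@@H]2CC[C@@H](O)Cc2cccc(Cl)c2)s1`, which has not yet been measured. The change is 3-chlorophenyl in place of 4-fluorophenyl on a saturated chain carbon, two bonds along the chain from an oxygen on a saturated carbon. For the measured compounds named here, no pair of measured compounds differs by this change alone, so its size must be judged indirectly. Compound 3 carries the 3-chlorophenyl group that enters here, on a different acid chain and without defined stereocentres, and its number in this assay is the lowest of the three. Against that, compound 1 and compound 2 show that their unsubstituted phenyl and 4-fluorophenyl groups give numbers that cannot be separated.

On this basis compound 4 is expected to give a somewhat lower number than compound 2, a step of a 1.8-fold lower number from compound 2 to compound 4 (0.26 log units; within the scatter), with the estimate placed at 12 nM and a range from 5 nM to 30 nM.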

Compound 4, half-maximal effective concentration: 0.6 nM
Beside the measured number, compound 4's estimate is 20-fold (1.30 log units) above it; measured number below the stated range.
By their numbers in this assay, from the lowest: compound 4; then compound 3; then compounds 2 and 1 (each within the scatter of the next).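

With the rest of the structure held constant, placing 3-chlorophenyl in place of 4-fluorophenyl on a saturated chain carbon, two bonds along the chain from an oxygen on a saturated carbon, produces a large change in this assay (a 37-fold lower number from compound 2 to compound 4 (1.56 log units; beyond the scatter)). For the compounds shown here, this is the first direct reading of the change, and it shows that this position is highly responsive to the substitution of the aromatic ring, even though the two groups match in their counts of heavy atoms, hydrogen-bond donors and acceptors, and differ only in the halogen and its place on the ring. Nothing measured here explains the size of this step.

Going by these compounds alone, the single step changes the halogen and its ring position together, so 3-fluorophenyl and 4-chlorophenyl would be needed to tell which of the two carries the effect. From the compounds shown here alone, it also remains open whether 3-chlorophenyl gives a step of similar size with the heptanoic acid chain when the stereocentres are defined, or whether a larger group such as 3-bromophenyl or 3-trifluoromethylphenyl is tolerated at this position.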